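Swapping a five-membered ring end group for 2-(oxiran-2-yl)ethyl

A few compounds are considered here, and "the series" means these few. Any claim that something is new, unique, unknown or untested is made for them only; others in the source may bear on it.

In a physicochemical assay for pharmacokinetics, tested at 1 mM, in the presence of a further agent that is not named here (on this read-out lower numbers stand for a shorter-lived compound and higher numbers for a longer-lived compound), compound 3 `O=C(/C=C/c1ccc(Cl)cc1Cl)N(O)CCCN1C(=O)C=CC1=O` stands highest at 4.95 h. Compound 2 `O=C(CI)NCCCN(O)C(=O)/C=C/c1ccc(Cl)cc1Cl` gives 0.183 h. Compound 1 `CS(=O)(=O)SCCCCCCN(O)C(=O)/C=C/c1ccc(Cl)cc1Cl` gives only a limit, < 0.0834 h. Compound 4 `O=C(/C=C/c1ccc(Cl)cc1Cl)N(O)CCCCCC1CO1` carries 2-(oxiran-2-yl)ethyl instead of the ring group of compound 3, on a saturated chain carbon, three bonds along the chain from an amide-type nitrogen (a group of 5 heavy atoms (4 carbon, 1 oxygen; one three-membered non-aromatic ring with 1 hetero atom) in place of a group of 7 heavy atoms (4 carbon, 1 nitrogen, 2 oxygen; one five-membered non-aromatic ring with 1 hetero atom), on a saturated chain carbon, three bonds along the chain from an amide-type nitrogen). Three measured steps change the group at this place: an at least 2.1-fold higher number from compound 1 to compound 2 (0.34 log units; beyond the scatter), an at least 59-fold higher number from compound 1 to compound 3 (1.77 log units; beyond the scatter) and a 27-fold higher number from compound 2 to compound 3 (1.43 log units; beyond the scatter). They show that this place can matter greatly, but none tests the entering group, so only a small rise, within the scatter, is expected. The expected step is a 1.6-fold higher number from compound 3 to compound 4 (0.21 log units; within the scatter). The estimated half-life for compound 4 is 8 h, with an expected range of 1.5 h to 40 h.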

Compound 4, half-life: 9.63 h
The estimate for compound 4 lay 1.2-fold (0.08 log units) below the measured number, within the range that was stated.
By their numbers in this assay, from the lowest: compound 2; then compounds 3 and 4 (each within the scatter of the next). At a limit, below all of these: compound 1.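

In this assay the step of a 1.9-fold higher number from compound 3 to compound 4 (0.29 log units; within the scatter) shows that 2-(oxiran-2-yl)ethyl serves as well as the ring group at this place, so a long half-life here does not need that five-membered ring. The step of a 53-fold higher number from compound 2 to compound 4 (1.72 log units; beyond the scatter) sets the new group far apart from ((iodomethyl)carbonyl)amino. Compound 1 gives only a limit, so the step of an at least 110-fold higher number from compound 1 to compound 4 (2.06 log units; beyond the scatter) is a bound and not a size: the limit of < 0.0834 h in this assay, at which 1 of the 4 values shown sits.

On these data alone, whether an amine or a carboxylic acid at this place would keep the half-life this long remains open. So does the effect of a longer chain.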